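The source may report more compounds than this note shows. Statements on the series, on what has been measured and on what is new or still open speak of the compounds shown alone.

Measured compounds in a functional assay on HeLa cells (Homo sapiens) for antiproliferative activity, read by MTT assay, with a stated time of 48 h; a higher number here means a weaker inhibitor, a lower number a stronger inhibitor:

compound 1 `CCN(CC)CCn1c(N)c(-c2nc3ccccc3[nH]2)c2nc(C#N)c(C#N)nc21` gives 11600 nM.
compound 2 `CCCn1c(N)c(-c2nc3ccccc3[nH]2)c2nc(C#N)c(C#N)nc21` gives > 50000 nM; this is a limit of the assay, not a number.
compound 3 `N#Cc1nc2c(-c3nc4ccccc4[nH]3)c(N)n(CCCNc3ccccc3)c2nc1C#N` gives 26300 nM.

Compound 1 holds the lowest number of the two numbers given; its nearest neighbour is compound 3, and the difference to compound 2 rests on a limit (the limit of > 50000 nM in this assay, at which 1 of the 3 values shown sits).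

Compound 4 `CN(C)CCCCCn1c(N)c(-c2nc3ccccc3[nH]2)c2nc(C#N)c(C#N)nc21` is not yet measured. Against compound 1 the change is 3-(dimethylamino)propyl in place of diethylamino on a saturated chain carbon, two bonds along the chain from an aromatic nitrogen.

For the measured compounds named here, two measured steps bear on this. The step of an at least 4.3-fold higher number from compound 1 to compound 2 (0.63 log units; beyond the scatter) removes the basic amine from the chain altogether and costs potency. The step of a 2.3-fold higher number from compound 1 to compound 3 (0.36 log units; beyond the scatter) replaces the amine with an anilino group and also costs potency, though less. Compound 4 keeps a basic amine on the chain, only further out and with the chain lengthened, so the loss seen in those two steps is not expected to recur in full; a small shift toward a higher number, near the edge of the scatter, is the expectation.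

For compound 4 the expected value in this assay is 16000 nM, with a range from 6000 nM to 42000 nM, which corresponds to an expected step of a 1.4-fold higher number from compound 1 to compound 4 (0.14 log units; within the scatter).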

Compound 4, half-maximal inhibitory concentration: 10800 nM
For compound 4 the middle estimate is 1.5-fold (0.17 log units) above the measured one, within the range that was stated.
By their numbers in this assay, from the lowest: compounds 4 and 1 (each within the scatter of the next); then compound 3. At a limit, above all of these: compound 2.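

Working from this assay, the place on a saturated chain carbon, two bonds along the chain from an aromatic nitrogen, accepts 3-(dimethylamino)propyl in place of diethylamino with a 1.1-fold lower number from compound 1 to compound 4 (0.03 log units; within the scatter), so the longer chain and its different amine end leave the number within the scatter. The chain ending in dimethylamino also stands clear of the anilino-ended chain, with a 2.4-fold lower number from compound 3 to compound 4 (0.39 log units; beyond the scatter), and of the unsubstituted chain, with an at least 4.6-fold lower number from compound 2 to compound 4 (0.66 log units; beyond the scatter), so among the compounds shown, compounds 1 and 4 share the lowest numbers whichever of the two chains they carry. The last of these steps is only a floor, as compound 2 gives a limit of the assay and not a number: the limit of > 50000 nM in this assay, at which 1 of the 4 values shown sits.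

Compound 4 differs from compound 1 in both chain length and the groups on the amine, and the two changes may offset each other or each do nothing, which the compounds shown cannot separate. A 2-(diethylamino)ethyl chain lengthened with the same diethylamino end, a 2-(dimethylamino)ethyl chain, or a ring amine such as morpholine or pyrrolidine at the chain end would address this.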